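The source may hold more compounds than are shown below. What is called first, only, known or untested is meant among the compounds shown, and "the series" means these compounds.

Measured in a functional assay on K562 cells (Homo sapiens) for antiproliferative activity, read by MTT assay, with a stated time of 48 h; a higher number here means a weaker inhibitor of growth, a lower number a stronger inhibitor of growth:
- compound 1 `CCOc1cc(NC(=O)CCCCCCC(=O)Nc2ccccc2N)cc2c1OCC([N+](=O)[O-])=C2`: 3360 nM
- compound 2 `CCOc1cc(NC(=O)CCCCCC(=O)Nc2cc(-c3ccc(C)s3)ccc2N)cc2c1OCC([N+](=O)[O-])=C2`: 2920 nM

In this assay, compound 2 gives 2920 nM, which lies within the scatter of compound 1 at 3360 nM. Going by the values given here, these two compounds differ in more than one place, so no single-change step has been measured.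

Next is compound 3 `CCOc1cc(NC(=O)CCCCCC(=O)Nc2ccccc2N)cc2c1OCC([N+](=O)[O-])=C2`, which differs from compound 2 as follows: hydrogen in place of 5-methylthiophen-2-yl on an aromatic carbon. This puts hydrogen in place of 5-methylthiophen-2-yl on an aromatic carbon.

Compound 1 also lacks the 5-methylthiophen-2-yl and gives 3360 nM, so loss of this group is not expected to bring a large change, though this is indirect evidence. The expected result is no step beyond the scatter, with an estimated 1.0-fold lower number from compound 2 to compound 3 (0.02 log units; within the scatter). For compound 3, the estimated value is 2800 nM, with an expected range of 1000 nM to 7500 nM.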

Compound 3, concentration for 50% growth inhibition: 3960 nM
For compound 3 the middle estimate is 1.4-fold (0.15 log units) below the measured one; the measured number falls inside the stated range.
By their numbers in this assay, from the lowest: compounds 2, 1 and 3 (each within the scatter of the next).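

In this assay, going by these compounds alone, hydrogen in place of 5-methylthiophen-2-yl on an aromatic carbon, para to an amino group, gives a 1.4-fold higher number from compound 2 to compound 3 (0.13 log units; within the scatter), the first direct reading at this position, and it shows no effect of this group beyond the scatter. Compound 3 also links compound 1 to the series through a single change in the chain: (2-aminophenyl)carbamoyl in place of ((2-aminophenyl)carbamoyl)methyl gives a 1.2-fold higher number from compound 1 to compound 3 (0.07 log units; within the scatter), so this chain change also stays within the scatter. No measurement at hand bears on the cause of either step.

On these data alone, whether a smaller group on this aromatic carbon, such as an amine or a carboxylic acid, would move the number beyond the scatter remains open. The same holds for a chain longer than that of compound 1.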